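Altering the amine substituent on the ether chain

The source may hold more compounds than are shown below. What is called first, only, known or untested is meant among the compounds shown, and "the series" means these compounds.

Compound 2 `CCO/C(O)=C1\C(COCCNCC(=O)NC)=NC(C)=C(C(=O)OC)C1c1ccccc1Cl` stands in a functional assay (aorta) with Rattus norvegicus as the target (on this read-out lower numbers stand for stronger inhibition and higher numbers for weaker inhibition), at 25.1 nM, level with compound 1 `CCO/C(O)=C1\C(COCCN(C)S(N)(=O)=O)=NC(C)=C(C(=O)OC)C1c1ccccc1Cl`, which gives 25.1 nM in this assay; the step of no change at the digits printed from compound 1 to compound 2 (within the scatter) lies within the scatter. Compound 3 `CCO/C(O)=C1\C(COCCNC(C)(C)C(N)=O)=NC(C)=C(C(=O)OC)C1c1ccccc1Cl` differs from compound 2 by 1-carbamoyl-1-methylethyl in place of (methylcarbamoyl)methyl on an amine nitrogen. Among the compounds with values here, the one measured step at this amine nitrogen, a larger change from compound 1 to compound 2, produced nothing beyond the scatter, so compound 3 is expected to stay close to compound 2 in this assay, at an estimated 25 nM with a range of 10 nM to 63 nM. The expected step is a 1.0-fold lower number from compound 2 to compound 3 (0.00 log units; within the scatter).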

Compound 3, half-maximal inhibitory concentration: 3.16 nM
Compound 3: the middle estimate sits 7.9-fold (0.90 log units) above what was measured; the whole stated range lies above it.
By their numbers in this assay, from the lowest: compound 3; then compounds 1 and 2 (each within the scatter of the next).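

In this assay, the amine nitrogen turns out to respond to its substituent: 1-carbamoyl-1-methylethyl in place of (methylcarbamoyl)methyl gives a 7.9-fold lower number from compound 2 to compound 3 (0.90 log units; beyond the scatter) and in place of the methyl(sulfamoyl)amino arrangement gives a 7.9-fold lower number from compound 1 to compound 3 (0.90 log units; beyond the scatter). The level values of compound 1 and compound 2 therefore did not mean that changes at this position leave the read-out untouched. Nothing measured here accounts for the lower number.

Going by these compounds, it remains open whether the step belongs to the two methyl groups or to the unsubstituted amide. A 1-carbamoylethyl group, or a carboxylic acid in place of the amide, would separate these.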